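The compounds below may be only part of what the source reports. "The series", "measured", "known", "first", "only" and "open" are said of these compounds alone.

Measured so far:
compound 1, `CCOc1ccc(Cc2nnc(CN(c3cccc(Cl)c3Cl)S(=O)(=O)c3ccc(C(F)(F)F)cc3)o2)cc1`: 6.31 nM
compound 2, `COc1ccc(Nc2nnc(CN(c3cccc(Cl)c3Cl)S(=O)(=O)c3ccc(C)cc3)o2)cc1`: 50.1 nM

Among the compounds with values here, compound 2 carries the higher of the two inhibition constants in a functional assay on CHO cells for antagonist activity at prostaglandin E2 receptor EP1 subtype (Homo sapiens), read by FLIPR and calcium flux; a higher number here means a weaker inhibitor, a lower number a stronger inhibitor; its gap to compound 1 lies beyond the usual scatter, but the two structures differ in more than one place, so their values show only that compound 2 is the weaker of the pair. Compound 3, `COc1ccc(Nc2nnc(CN(c3cccc(Cl)c3Cl)S(=O)(=O)c3ccc(C(F)(F)F)cc3)o2)cc1`, keeps everything of compound 2 except one change: trifluoromethyl in place of methyl on an aromatic carbon. Within the data shown here, no step between measured compounds isolates this change. Among the measured compounds shown here, still, the only measured compound bearing the trifluoromethyl group, compound 1, gives 6.31 nM in this assay, which leaves room for a downward step. Compound 3 is therefore expected to come in lower than compound 2, with the step of a 2.5-fold lower number from compound 2 to compound 3 (0.40 log units; beyond the scatter) estimated as modest. The inhibition constant of compound 3 in this assay is estimated at 20 nM, within a range from 6 nM to 63 nM.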

Compound 3, inhibition constant: 63.1 nM
For compound 3 the middle estimate is 3.2-fold (0.50 log units) below the measured one; measured number above the stated range.
By their numbers in this assay, from the lowest: compound 1; then compounds 2 and 3 (each within the scatter of the next).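

In this assay the exchange of methyl for trifluoromethyl, on an aromatic carbon para to a large group, gives a 1.3-fold higher number from compound 2 to compound 3 (0.10 log units; within the scatter) and so does not separate the two compounds while the (4-methoxyphenyl)amino group is present. With trifluoromethyl held fixed, (4-methoxyphenyl)amino in place of 4-ethoxybenzyl gives a 10-fold higher number from compound 1 to compound 3 (1.00 log units; beyond the scatter) and thus shows that trifluoromethyl alone does not confer the low number of compound 1. No measurement at hand bears on what lies behind either step.

The compounds shown leave open whether the exchange of methyl for trifluoromethyl would read the same with 4-ethoxybenzyl present, and how a chlorine or a nitrile on that aromatic carbon would compare. They also leave open whether the larger step goes with the ethoxy group or with the amino link, as these two differences travel together.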